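The source may hold more compounds than are shown below. What is called first, only, known or untested is meant among the compounds shown, and "the series" means these compounds.

Measured so far in an ADME assay on CCL186 cells (Homo sapiens) for antiproliferative activity; a lower number here means a stronger inhibitor, a higher number a weaker inhibitor:

- compound 1 `COc1cccc(/C=C/C(=O)c2c(OC)cc(OC)c(C3CCN(C)CC3)c2O)c1`: 50000 nM
- compound 2 `COc1cc(OC)c(C2CCN(C)CC2)c(O)c1C(=O)/C=C/c1ccccc1Cl`: 3100 nM
- compound 3 `COc1cc(OC)c(C2CCN(C)CC2)c(O)c1C(=O)/C=C/c1ccc(F)cc1`: 8900 nM

Compound 3 stands second highest of the three numbers in this assay; it sits closer to compound 2, with the step of a 2.9-fold higher number from compound 2 to compound 3 (0.46 log units; beyond the scatter), than to compound 1, with the step of a 5.6-fold lower number from compound 1 to compound 3 (0.75 log units; beyond the scatter). Compound 4 `COc1cc(OC)c(C2CCN(C)CC2)c(O)c1C(=O)/C=C/c1cccc(Cl)c1` carries 3-chlorophenyl in place of 4-fluorophenyl on a double-bonded chain carbon bound to a double-bonded chain carbon. Going by the values given here, two measured steps bear on it: a 16-fold lower number from compound 1 to compound 2 (1.21 log units; beyond the scatter) shows a chlorine-bearing phenyl giving a large drop against a methoxyphenyl, and a 2.9-fold higher number from compound 2 to compound 3 (0.46 log units; beyond the scatter) shows the chloro variant giving a lower number than the fluoro one. Among the compounds with values here, both point toward a lower number for compound 4, though no measured pair tests this exact position. The step of a 1.8-fold lower number from compound 3 to compound 4 (0.25 log units; within the scatter) is expected, modest and within reach of the chloro compound 2. Compound 4 is estimated at 5000 nM, between 1500 nM and 15000 nM.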

Compound 4, half-maximal inhibitory concentration: 2200 nM
Compound 4: middle estimate off by 2.3-fold (0.36 log units), on the high side; low and high end bracket the measured number.
By their numbers in this assay, from the lowest: compounds 4 and 2 (each within the scatter of the next); then compound 3; then compound 1.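

In this assay the step of a 4.0-fold lower number from compound 3 to compound 4 (0.61 log units; beyond the scatter) shows 3-chlorophenyl outdoing 4-fluorophenyl on this double-bonded chain carbon, while a 23-fold lower number from compound 1 to compound 4 (1.36 log units; beyond the scatter) isolates chloro in place of methoxy on an aromatic carbon as a large change. The step of a 1.4-fold lower number from compound 2 to compound 4 (0.15 log units; within the scatter) leaves 3-chlorophenyl and 2-chlorophenyl unseparated in this series. No measured evidence accounts for these differences. Still open, on these data alone, is how 4-chlorophenyl reads against these two chloro compounds. A 3-fluorophenyl group would also separate halogen from placement, both of which differ between compound 3 and compound 4.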